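Methylamino in place of chloro on the shared core

A few compounds are considered here, and "the series" means these few. Any claim that something is new, unique, unknown or untested is made for them only; others in the source may bear on it.

Of the compounds shown here, two have so far been measured in a functional assay on HCT-116 cells (Homo sapiens) for antiproliferative activity, read by MTT assay, with a stated time of 48 h; a higher number here means a weaker inhibitor, a lower number a stronger inhibitor. Compound 1 (`CCCCCCCCCC(CCO)n1cnc2c(NC)ncnc21`) gives 5410 nM and compound 2 (`CCCCCCCCCCC(CCO)n1cnc2c(Cl)ncnc21`) gives 4930 nM, two values within the scatter of each other. Compound 3 (`CCCCCCCCCCC(CCO)n1cnc2c(NC)ncnc21`) departs from compound 2 in one place, with methylamino in place of chloro on an aromatic carbon. Among the compounds with values here, no measured pair isolates this change. However, compound 1 already carries methylamino and gives 5410 nM, so no step beyond the scatter is expected in this assay, in either direction. For compound 3 the estimated value is 5000 nM (2500 nM to 10000 nM).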

Compound 3, half-maximal inhibitory concentration: 12700 nM
For compound 3 the middle estimate is 2.5-fold (0.40 log units) below the measured one; measured number above the stated range.
By their numbers in this assay, from the lowest: compounds 2 and 1 (each within the scatter of the next); then compound 3.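

In this assay, methylamino in place of chloro on an aromatic carbon brings a 2.6-fold higher number from compound 2 to compound 3 (0.41 log units; beyond the scatter) on this chain, so the change is not silent at this position. Methyl in place of hydrogen on a saturated chain carbon gives a 2.3-fold higher number from compound 1 to compound 3 (0.37 log units; beyond the scatter) with methylamino held in place, so the chain end also counts. Nothing measured here accounts for either step.

On these data alone, whether a plain amino group or dimethylamino at this position would track methylamino or chloro remains open. So does whether a longer chain would extend the step seen with the added methyl.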